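A few compounds are considered here, and "the series" means these few. Any claim that something is new, unique, unknown or untested is made for them only; others in the source may bear on it.

Of the compounds shown here, two have been tested in a functional assay on HL-60 cells (Homo sapiens) for activation, read by flow cytometry, with a stated time of 4 days; a higher number here means that more compound is needed for the effect, a lower number that less compound is needed. Compound 1 `COc1ccc(-n2cnc3cnc(-c4ccccc4C)cc32)cc1OC` gives 69 nM, and compound 2 `COc1ccc(-n2cnc3cnc(-c4ccccc4OC(F)(F)F)cc32)cc1OC` gives 2500 nM, so compound 2 stands highest of the two numbers, with compound 1 the nearest, as the step of a 36-fold higher number from compound 1 to compound 2 (1.56 log units; beyond the scatter) shows. That single step concerns a change on an aromatic carbon of one of the outer rings. Compound 3 `FC(F)Oc1ccc(-n2cnc3cnc(-c4ccccc4OC(F)(F)F)cc32)cc1` differs from compound 2 at another place altogether: 4-(difluoromethoxy)phenyl in place of 3,4-dimethoxyphenyl on an aromatic nitrogen. Among the measured compounds shown here, no measured step touches the group on the aromatic nitrogen, so the one step at hand offers no guide to this change, and the expectation has to rest on compound 2 alone. For compound 3 a step of no change at the digits printed from compound 2 to compound 3 (within the scatter) is expected, that is, none beyond the scatter, though with wide uncertainty. The value expected for compound 3 is 2500 nM, within a range from 700 nM to 9000 nM.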

Compound 3, half-maximal effective concentration: 6900 nM
Compound 3: the middle estimate sits 2.8-fold (0.44 log units) below what was measured, within the range that was stated.
By their numbers in this assay, from the lowest: compound 1; then compound 2; then compound 3.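

The swap of 3,4-dimethoxyphenyl for 4-(difluoromethoxy)phenyl on the aromatic nitrogen gives a 2.8-fold higher number from compound 2 to compound 3 (0.44 log units; beyond the scatter) in this assay, so this position also affects the result, although the step is modest. The two groups have the same count of heavy atoms, and the entering group has one hydrogen-bond acceptor fewer, so a change that keeps that count still shifts the number beyond the scatter. Nothing available explains the shift.

Going by these compounds, this step was read only with the trifluoromethoxy group on the outer ring, so it remains open whether the same swap would have a similar effect alongside the methyl group of compound 1. Also open, on these data alone, is how a phenyl ring carrying a single methoxy, an amine or a carboxylic acid would behave at this position.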